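Fluoro in Place of Ethynyl on a Shared Core

The source may hold more compounds than are shown below. What is called first, only, known or untested is meant among the compounds shown, and "the series" means these compounds.

Two measured compounds share a common core and differ only in what sits on one aromatic ring. Compound 1 `O=C(NCCCCc1ccccc1)c1cccc(C2SCC(=O)N2c2ccccn2)c1` and compound 2 `C#Cc1cc(C(=O)NCCCCc2ccccc2)cc(C2SCC(=O)N2c2ccccc2OC)c1` were both tested in a functional assay on HOS-TE85 cells (Homo sapiens) for inhibition, read by CCK-8 assay, with a stated time of 72 h; on this read-out lower numbers stand for stronger inhibition and higher numbers for weaker inhibition. In this assay compound 1 gives 19.7 nM, and compound 2 gives 40.8 nM. Compound 2 therefore stands at the higher of the two numbers, the weaker inhibition, with compound 1 a step beyond the scatter below it.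

Compound 3 `COc1ccccc1N1C(=O)CSC1c1cc(F)cc(C(=O)NCCCCc2ccccc2)c1` has not yet been measured. Within the data shown here, its one difference from compound 2 is small: fluoro in place of ethynyl on an aromatic carbon. Both groups are uncharged and carry no hydrogen-bond donors or acceptors, and the rest of the molecule is unchanged. Among the measured compounds shown here, no measured pair in this set shows this exchange, so there is nothing to read a direction from. The expectation is a step from compound 2 to compound 3 of about a 1.0-fold lower number from compound 2 to compound 3 (0.01 log units; within the scatter), which is no change beyond the scatter. Compound 3 is estimated to give 40 nM in this assay, with a range from 15 nM to 110 nM.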

Compound 3, half-maximal inhibitory concentration in the HOS-TE85 assay: 40.9 nM
For compound 3 the middle estimate is 1.0-fold (0.01 log units) below the measured one; the measured number falls inside the stated range.
By their numbers in the HOS-TE85 assay, from the lowest: compound 1; then compounds 2 and 3 (each within the scatter of the next).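

Among these compounds, in the HOS-TE85 assay fluoro in place of ethynyl on an aromatic carbon gives a 1.0-fold higher number from compound 2 to compound 3 (0.00 log units; within the scatter) and so shows what the earlier compounds could not: at this place, meta to two large groups, the two groups cannot be told apart by this read-out. The exchange is not a trivial one on paper, since a group of two carbons with a triple bond leaves and a single fluorine atom enters, yet the number stays within the scatter. In a physicochemical assay for solubility, read by turbidimetry, measured as kinetic solubility, at pH 7.4 (a higher number here means a more soluble compound, a lower number a less soluble compound), compound 2 gives 10000 nM and compound 3 gives 10000 nM with no difference at the digits printed, so this second read-out does not separate the two groups either.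

On these data alone, whether an amine, a carboxylic acid or a longer chain at this same place would also leave the number in the HOS-TE85 assay where it stands remains open, and one exchange on one core cannot say how far this tolerance reaches. Nothing measured here offers a reason why the two groups read alike.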